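The source may hold more compounds than are shown below. What is called first, only, known or untested is meant among the compounds shown, and "the series" means these compounds.

Working notes on the series in an ADME assay on RAW264.7 cells (Mus musculus) for cytotoxicity, read by MTT assay, with a stated time of 24 h; on this read-out higher numbers stand for lower toxicity in this test and lower numbers for higher toxicity in this test.

Compound 1 `O=C(Nc1ccc(Cl)cc1F)c1ccccc1OCc1ccc(F)cc1F` is an open-chain amide. In this assay compound 1 gives > 40000 nM, which is a limit of the assay and not a number. Compound 2 `O=c1oc2ccccc2c(=O)n1-c1ccc(Cl)cc1F` carries the same aryl group on a cyclic core. In this assay compound 2 gives 26500 nM, the only number shown. Compound 3 `COc1ccc2c(=O)n(-c3ccc(Cl)cc3F)c(=O)oc2c1` adds a methoxy to the core of compound 2. In this assay compound 3 gives > 40000 nM, again a limit of the assay. Among the measured compounds shown here, the single measured step, an at least 1.5-fold higher number from compound 2 to compound 3 (0.17 log units; that floor lies within the scatter), is methoxy in place of hydrogen on an aromatic carbon; its floor lies within the scatter, and the reading sits at the limit of > 40000 nM in this assay, at which 2 of the 3 values shown sit.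

Compound 4 `O=c1oc2ccccc2c(=O)n1-c1ccc(F)cc1F` differs from compound 2 by fluoro in place of chloro on an aromatic carbon, meta to a fluoro group and para to a large group. For the measured compounds named here, no measured step touches this position or this halogen exchange; the one step available was small. For compound 4 the expected step is therefore a 1.1-fold higher number from compound 2 to compound 4 (0.05 log units; within the scatter), none beyond the scatter. Compound 4 is estimated at 30000 nM, with a range from 13000 nM to 70000 nM, and the assay may well report only a limit.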

Compound 4, half-maximal cytotoxic concentration: > 40000 nM
Compound 4 gave a limit, no number; the forecaster's own chance of this, stated with the estimate: 45%; middle value at least 1.3-fold (0.12 log units) from the limit.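

Fluoro in place of chloro on an aromatic carbon, para to a large group, gives the first reading at this position on the aryl group: an at least 1.5-fold higher number from compound 2 to compound 4 (0.17 log units; that floor lies within the scatter). Among the compounds shown here, until now the only change read on the cyclic series was on the core, an at least 1.5-fold higher number from compound 2 to compound 3 (0.17 log units; that floor lies within the scatter), so this result extends the picture to the halogen, and in this assay the two changes now read alike, each with a floor inside the scatter and neither giving a size. Compound 4 is not resolved from the compounds at the top of the range, and the series now rests mostly on one reading: the limit of > 40000 nM in this assay, at which 3 of the 4 values shown sit.

For the compounds shown here, with compound 2 the only one carrying a number, the true size of both steps stays open, and compound 1, compound 3 and compound 4 cannot be ordered among themselves. Also open, from the compounds shown here alone, is whether anything at this position moves the reading beyond the scatter in either direction, for instance an amine or a carboxylic acid in place of the halogen, and whether such a group would bring the value down from the limit.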